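The source may report more compounds than this note shows. Statements on the series, on what has been measured and on what is new or still open speak of the compounds shown alone.

Measured compounds:
- compound 1, `Nc1ccc(-c2nc3cc(F)ccc3s2)cc1I`: 130 nM
- compound 2, `Cc1cc(-c2nc3ccc(F)cc3s2)ccc1N`: no result reported

Compound 1 shows 130 nM in a functional assay on T47D cells (Breast, Homo sapiens) for inhibition; a higher number here means a weaker inhibitor of growth, a lower number a stronger inhibitor of growth. Compound 2 differs from compound 1 in more than one place, and for compound 2 there is no result reported in this assay, so it cannot be placed against compound 1 on the numbers shown.

Compound 3, `Cc1cc(-c2nc3ccccc3s2)ccc1N`, is the not yet measured neighbour of compound 2. The change between them is hydrogen in place of fluoro on an aromatic carbon. For the measured compounds named here, no measured pair with this same change is available, so the size and direction of the step cannot be read from the data. A step of modest size, within or just beyond the scatter of this assay, in either direction, is expected.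

With only compound 1 as a measured anchor, compound 3 is expected to reach about 60 nM in this assay, with a range from 5 nM to 600 nM.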

Compound 3, concentration for 50% growth inhibition: 20 nM
The estimate for compound 3 lay 3.0-fold (0.48 log units) above the measured number; the range from low to high includes it.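

No step can be read between compound 2 and compound 3 in this assay, as only compound 3 carries a number there. Going by these compounds, what swapping fluoro for hydrogen does to growth inhibition stays open. Nothing available offers an explanation for the value of compound 3.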